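A few compounds are considered here, and "the series" means these few. Any claim that something is new, unique, unknown or untested is made for them only; others in the source may bear on it.

Of the compounds shown here, three from this series have already been measured in an assay on isolated protein for agonist activity at Bile acid receptor (Homo sapiens), read by AlphaScreen, with a stated time of 30 min; a higher number here means a larger maximal response, a lower number a smaller maximal response. Compound 1 `Cc1ccccc1-n1nc(C)c2c1NC(=O)[C@H](C)S[C@@H]2c1ccc(-c2ccoc2)cc1` gives 40% in this assay, the lowest of the three results. Compound 2 `CCCc1ccccc1-n1nc(C)c2c1NC(=O)[C@H](C)S[C@@H]2c1ccc(Oc2ccccc2)cc1` reaches 240%, and compound 3 `Cc1nn(-c2ccccc2Cl)c2c1C(c1ccc(Oc3ccccc3)cc1)SC(C)C(=O)N2` reaches 57%. Compound 1 therefore stands well below both neighbours: compound 3 is closer but still beyond the usual scatter, and compound 2 lies far above it.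

Compound 4 `COc1cccc(Oc2ccc([C@H]3S[C@@H](C)C(=O)Nc4c3c(C)nn4-c3ccccc3C)cc2)c1` differs from compound 1 in a single place: 3-methoxyphenoxy in place of furan-3-yl on an aromatic carbon. The change occurs on an aromatic carbon of a six-membered aromatic ring of carbon only, para to a large group. Among the compounds with values here, no pair of measured compounds that differs in just this way has been compared, so the size of the step is uncertain. Because compound 2 shows 240% while compound 3 shows 57%, larger groups of this kind appear compatible with both high and modest responses. A rise beyond the scatter is expected, with the step from compound 1 to compound 4 estimated as a number 50 percentage points higher from compound 1 to compound 4 (beyond the scatter). Compound 4 is expected to give about 90% in this assay, within a range from 35% to 220%.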

Compound 4, largest response reached (reported as efficacy), in percent of the reference or control that the assay uses: 120%
Compound 4: the middle estimate sits 30 percentage points below what was measured; the measured number falls inside the stated range.
By their numbers in this assay, from the lowest: compound 1; then compound 3; then compound 4; then compound 2.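

In this assay, putting 3-methoxyphenoxy in place of furan-3-yl on this aromatic carbon, para to a large group, gives a number 80 percentage points higher from compound 1 to compound 4 (beyond the scatter). Within the data shown here, this is the first comparison in which only this one place changes, so it shows that the group here can by itself shift the maximal response by a large amount, and that the larger group entering here is compatible with a higher response than the furan-3-yl leaving. No measurement shown explains the rise.

A single pair cannot separate the part played by the methoxy group from that of the rest of the 3-methoxyphenoxy group. From the compounds shown here alone, how the response would change with a carboxylic acid, an amine or a longer carbon chain on this carbon remains open.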